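Pyridin-4-yl for 4-fluorophenyl on compound 3

The source may report more compounds than this note shows. Statements on the series, on what has been measured and on what is new or still open speak of the compounds shown alone.

In a physicochemical assay for solubility, at pH 7 (a lower number here means a less soluble compound, a higher number a more soluble compound), compound 3 `CC(C)(C)C(=O)N1Cc2c(NC(=O)c3ccc(F)cc3)n[nH]c2C1(C)C` gives 235000 nM and compound 1 `CC(C)(C)C(=O)N1Cc2c(NC(=O)c3cccnc3)n[nH]c2C1(C)C` gives 207000 nM, two numbers within the scatter of each other. Compound 2 `CC1(C)c2[nH]nc(NC(=O)c3ccc(F)cc3)c2CN1C(=O)C1CCN(C2CC2)CC1` gives > 225000 nM, which is a limit and not a number. This leaves a step that the limit leaves unreadable from compound 2 to compound 3, so that change offers no guide.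

Compound 4 `CC(C)(C)C(=O)N1Cc2c(NC(=O)c3ccncc3)n[nH]c2C1(C)C` carries pyridin-4-yl in place of 4-fluorophenyl on a carbonyl carbon. Within the data shown here, the one readable step on that carbonyl carbon is a 1.1-fold higher number from compound 1 to compound 3 (0.06 log units; within the scatter), with 4-fluorophenyl in place of pyridin-3-yl, and it lies within the scatter. From compound 1 and that step, no change beyond the scatter is expected in this assay. The estimated step is a 1.1-fold lower number from compound 3 to compound 4 (0.04 log units; within the scatter). Compound 4 is expected at 215000 nM, with an estimated range of 130000 nM to 300000 nM.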

Compound 4, solubility: 205000 nM
For compound 4 the middle estimate is 1.0-fold (0.02 log units) above the measured one; the measured number falls inside the stated range.
By their numbers in this assay, from the lowest: compounds 4, 1 and 3 (each within the scatter of the next).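

In this assay, pyridin-4-yl in place of 4-fluorophenyl on the carbonyl carbon gives a 1.1-fold lower number from compound 3 to compound 4 (0.06 log units; within the scatter), and pyridin-4-yl in place of pyridin-3-yl gives a 1.0-fold lower number from compound 1 to compound 4 (0.00 log units; within the scatter). Both steps lie within the scatter, so compounds 1, 3 and 4 are not told apart, and this position now has three aromatic groups that this assay does not separate.

Still open, on these data alone, is whether an aliphatic amine or a carboxylic acid on this ring would give a step beyond the scatter. One value in this set is a limit and not a number: the limit of > 225000 nM in this assay, at which 1 of the 4 values shown sits.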